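A Trifluoromethyl-for-Chloro Exchange Awaiting Measurement

The source may report more compounds than this note shows. Statements on the series, on what has been measured and on what is new or still open speak of the compounds shown alone.

Compound 1, `COc1cc2cc(Oc3ccc(NC(=O)Nc4cccc(C(F)(F)F)c4)cc3)c(C)nc2cc1OC`: 24100 nM
Compound 2, `COc1cc2cc(Oc3ccc(NC(=O)Nc4ccc(Cl)c(C(F)(F)F)c4)cc3)c(C)nc2cc1OC`: 13700 nM

All numbers here come from a functional assay on HOP-62 cells (Homo sapiens) for inhibition, read by sulforhodamine B assay, with a stated time of 48 h; on this read-out higher numbers stand for lower toxicity in this test and lower numbers for higher toxicity in this test. Within the data shown here, compound 2 gives the lower of the two numbers measured so far; its nearest neighbour is compound 1, and the one step between them, a 1.8-fold lower number from compound 1 to compound 2 (0.25 log units; within the scatter), lies within the scatter, so the two cannot be ranked against each other.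

Compound 3, `COc1cc2cc(Oc3ccc(NC(=O)Nc4ccc(Cl)c(Cl)c4)cc3)c(C)nc2cc1OC`, has not yet been measured. It differs from compound 2 in a single place: chloro in place of trifluoromethyl on an aromatic carbon. Among the measured compounds shown here, the only measured step bearing on this region of the molecule is a 1.8-fold lower number from compound 1 to compound 2 (0.25 log units; within the scatter), which concerned a chloro entering where hydrogen had stood, not a trifluoromethyl leaving; it was small and within the scatter. For the measured compounds named here, no measured pair speaks directly to the exchange now made. On that basis the expected step in this assay is a 1.1-fold higher number from compound 2 to compound 3 (0.04 log units; within the scatter), that is, nothing beyond the scatter in either direction. Compound 3 is therefore estimated at 15000 nM, with a range from 6000 nM to 40000 nM.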

Compound 3, concentration lethal to 50% of the cells: 34400 nM
For compound 3 the middle estimate is 2.3-fold (0.36 log units) below the measured one; the measured number falls inside the stated range.
By their numbers in this assay, from the lowest: compounds 2, 1 and 3 (each within the scatter of the next, the first and the last beyond it).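

In this assay, among these compounds, the exchange of trifluoromethyl for chloro on this aromatic carbon, ortho to a chloro group, gives the first step in this part of the molecule that lies beyond the scatter (a 2.5-fold higher number from compound 2 to compound 3 (0.40 log units; beyond the scatter)). The identity of the group on this carbon therefore registers in this test, modestly, and the change runs toward the higher number, which stands for lower toxicity here. Among the compounds shown here, the comparison of the 3,4-dichlorophenyl compound with the 3-(trifluoromethyl)phenyl compound does not separate them (a 1.4-fold higher number from compound 1 to compound 3 (0.15 log units; within the scatter)), so among the three compounds only the pair that differs by this exchange stands apart, and nothing measured on these compounds accounts for that step.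

It remains open whether the same exchange would give a step of this size without the chloro group ortho to the changing position, since every comparison of the two groups shown here has a different neighbouring pattern or only this one pair. Also open, as far as these compounds go, is how a nitrile, a methoxy group or an amine on the same carbon would stand against chloro and trifluoromethyl in this assay.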